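The source may report more compounds than this note shows. Statements on the series, on what has been measured and on what is new or still open speak of the compounds shown alone.

For the measured compounds named here, compound 1 `COc1cc(-c2cc(/C=C/C(=O)c3ccc(N)cc3)[nH]n2)cc(OC)c1OC` is one of two compounds measured in a functional assay on UACC-257 cells (Homo sapiens) for cytotoxicity, read by sulforhodamine B assay, with a stated time of 48 h, tested at 10 uM; a higher number here means a weaker effect of the compound at the concentration tested, a lower number a stronger effect. In this assay compound 1 gives -59%, the higher of the two numbers, while compound 2 `COc1ccc(-c2cc(/C=C/C(=O)c3ccc(OC)c(OC)c3)[nH]n2)cc1` gives -67%; the two values lie within the scatter of each other, so no order between them can be drawn. Compound 3 `COc1cc(-c2cc(/C=C/C(=O)c3ccc(Cl)c(Cl)c3)[nH]n2)cc(OC)c1OC` has not yet been measured. It differs from compound 1 in one place: 3,4-dichlorophenyl in place of 4-aminophenyl on a carbonyl carbon. Going by the values given here, no measured pair shows the effect of such a change, so for compound 3 no step beyond the scatter is expected, and the estimated step of a number 4 percentage points lower from compound 1 to compound 3 (within the scatter) is small. Compound 3 is accordingly expected to give about -63%, between -88% and -35%.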

Compound 3, a percentage reported as activity, at one concentration (the size of the read-out at that concentration, not a potency): 66%
For compound 3 the middle estimate is 129 percentage points below the measured one; measured number above the stated range.
By their numbers in this assay, from the lowest: compounds 2 and 1 (each within the scatter of the next); then compound 3.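

Here the group on the carbonyl carbon turns out to matter strongly: 3,4-dichlorophenyl in place of 4-aminophenyl gives a number 125 percentage points higher from compound 1 to compound 3 (beyond the scatter) in this assay, so this position is not indifferent to change. The sign of the read-out also flips, from -59% for compound 1 to 66% for compound 3. No measurement at hand accounts for this step.

From the compounds shown here alone, whether a plain phenyl, or a phenyl carrying a single chlorine or a hydroxyl, would fall nearer compound 1 or compound 3 stays open. So does whether the same exchange would act alike on the core of compound 2.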